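This account rests on a few compounds, and the source may have more. Where it says the series, first, only, none or still open, it means among the compounds named here.

Of the compounds shown here, two have been measured in an assay on ileum (strain Hartley) with 5-hydroxytryptamine receptor 3A (Cavia porcellus) as the target (on this read-out lower numbers stand for smaller maximal responses and higher numbers for larger maximal responses), and both share one core. Compound 1, `Cc1cccc2nc(N3CCN(C)CC3)oc12`, gives 0.58 in this assay. Compound 2, `CCc1cc(Cl)cc2nc(N3CCN(C)CC3)oc12`, which carries an ethyl group and a chloro group on the same core, gives 0.17. Among the measured compounds shown here, that puts compound 2 at the lowest point of the two numbers so far; compound 1 sits a clear distance higher, beyond the usual scatter of the measurement.

The next compound, compound 3, `CCc1cccc2nc(N3CCN(C)CC3)oc12`, has not yet been measured. It differs from compound 2 in a single place: hydrogen in place of chloro on an aromatic carbon.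

For the measured compounds named here, no step between two measured compounds shows what removing a chloro group does on its own here, so the expectation rests on little. Still, compound 1, which also bears no chloro group, gives 0.58, well above compound 2. On that basis the step from a number 0.28 higher from compound 2 to compound 3 (beyond the scatter) is expected to be upward and larger than the scatter. Compound 3 is therefore estimated at about 0.45, with a likely range from 0.2 to 0.7.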

Compound 3, intrinsic activity: the largest response reached, as a fraction of the reference agonist's: 0.15
Estimate against measurement, compound 3: 0.30 above; measured number outside the range, below it.
By their numbers in this assay, from the lowest: compounds 3 and 2 (each within the scatter of the next); then compound 1.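

In this assay, hydrogen in place of chloro on the aromatic carbon meta to the ethyl group gives a number 0.020 lower from compound 2 to compound 3 (within the scatter), so with the ethyl group in place, this read-out cannot tell the chloro compound from the one without it. The large change comes from the chain instead: methyl in place of hydrogen on the saturated chain carbon bound to an aromatic carbon, which turns a methyl group into an ethyl group, gives a number 0.43 lower from compound 1 to compound 3 (beyond the scatter), so this small extension on the shared core goes with a much smaller maximal response. The data here offer no measured reason for either the flat step at the chloro position or the large step at the chain.

The compounds shown leave open whether the chloro group would count for as little alongside a methyl group as it does alongside an ethyl group. They also leave open how the maximal response would respond to a longer chain such as propyl in place of the ethyl group, or to a different group such as an amine in place of the chloro group.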